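The source may report more compounds than this note shows. Statements on the series, on what has been measured and on what is new or still open speak of the compounds shown alone.

In a functional assay on SW620/5-FU cells (Homo sapiens) for cytotoxicity, read by MTT assay, with a stated time of 48 h, in the presence of a further agent that is not named here (on this read-out lower numbers stand for an effect already at smaller amounts and higher numbers for an effect only at larger amounts of compound), compound 1 `Cc1nn(C)c2nc(NNC(=O)Nc3cc(Cl)nc(Cl)c3)cc(C3CC3)c12` gives 80800 nM, compound 2 `COc1ccc(-c2cc(NNC(=O)Nc3cc(Cl)nc(Cl)c3)nc3c2c(C)nn3C)cc1` gives 9700 nM and compound 3 `Cn1ncc2c(-c3ccc(F)cc3)cc(NNC(=O)Nc3cc(Cl)cc(Cl)c3)nc21` gives 54300 nM. Compound 3 therefore lies within the scatter of compound 1, and its number is clearly higher than that of compound 2. Compound 4 `Cn1ncc2c(-c3ccc(F)cc3)cc(NNC(=O)Nc3cc(Cl)nc(OCCF)c3)nc21` carries 2-chloro-6-(2-fluoroethoxy)pyridin-4-yl in place of 3,5-dichlorophenyl on an amide-type nitrogen. Among the measured compounds shown here, the only measured single change, an 8.3-fold lower number from compound 1 to compound 2 (0.92 log units; beyond the scatter), put 4-methoxyphenyl in place of cyclopropyl on an aromatic carbon, which is a different place, so it gives no direct guide. No step beyond the scatter is therefore expected in this assay, and the estimated step is a 1.6-fold lower number from compound 3 to compound 4 (0.19 log units; within the scatter). The expected value for compound 4 is 35000 nM, with an estimated range of 10000 nM to 100000 nM.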

Compound 4, half-maximal effective concentration: 29300 nM
Compound 4: the middle estimate sits 1.2-fold (0.08 log units) above what was measured, and the stated range covers the measured number.
By their numbers in this assay, from the lowest: compound 2; then compounds 4, 3 and 1 (each within the scatter of the next, the first and the last beyond it).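

In this assay, among the compounds shown here, this is the first view of the group on the amide-type nitrogen: 2-chloro-6-(2-fluoroethoxy)pyridin-4-yl replaces 3,5-dichlorophenyl, giving a 1.9-fold lower number from compound 3 to compound 4 (0.27 log units; within the scatter). A larger group with a hetero atom in its ring and two hydrogen-bond acceptors is therefore accommodated here with no change beyond the scatter. No measurement on hand explains this result. As far as these compounds go, whether an amine or a carboxylic acid in place of the 2-fluoroethoxy chain would shift the number remains open.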